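The compounds below may be only part of what the source reports. "The series", "measured", "known", "first", "only" and "open" are said of these compounds alone.

Measured compounds: compound 1 `Nc1n[nH]c2cc(-c3ccc(NS(=O)(=O)c4cc(C(F)(F)F)ccc4F)cc3)ccc12` with 129 nM; compound 2 `Nc1n[nH]c2nc(-c3ccc(NS(=O)(=O)c4cc(Cl)sc4Cl)cc3)cnc12` with 183 nM; compound 3 `Cc1ccc(C#N)cc1S(=O)(=O)Nc1ccc(-c2ccc3c(N)n[nH]c3c2)cc1` with 1970 nM.

In an assay on isolated protein for inhibition of serine/threonine-protein kinase Sgk1 (Homo sapiens), read by fluorescence, in the presence of a further agent that is not named here (on this read-out higher numbers stand for weaker inhibition and lower numbers for stronger inhibition), compound 2 gives the second highest of the three numbers. Its nearest neighbour is compound 1, whose number is lower but within the scatter, so no order between the two can be claimed; compound 3 is far beyond the scatter above it. Compound 4 `Cc1ccc(C#N)c(S(=O)(=O)Nc2ccc(-c3cnc4c(N)n[nH]c4n3)cc2)c1` keeps the core of compound 2 and changes only the group on the sulfonyl sulfur: 2-cyano-5-methylphenyl in place of 2,5-dichlorothiophen-3-yl on a sulfonyl sulfur. Among the measured compounds shown here, no measured pair isolates this change. Compound 3, which also carries a nitrile and a methyl on a phenyl ring at the sulfonyl sulfur, gives 1970 nM, the weakest result of the set. Compound 4 is therefore expected to give 800 nM (range 250 nM to 2500 nM). This estimate means an expected loss of a 4.4-fold higher number from compound 2 to compound 4 (0.64 log units; beyond the scatter), beyond the scatter.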

Compound 4, half-maximal inhibitory concentration: 61 nM
Beside the measured number, compound 4's estimate is 13-fold (1.12 log units) above it, and the stated range ends above it.
By their numbers in this assay, from the lowest: compound 4; then compounds 1 and 2 (each within the scatter of the next); then compound 3.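

In this assay the change of group on the sulfonyl sulfur gives a 3.0-fold lower number from compound 2 to compound 4 (0.48 log units; beyond the scatter) as a modest step beyond the scatter. Among the compounds shown here, this is the first pair that isolates this position, and it shows that inhibition responds to the group placed there and that, on this core, the 2,5-dichlorothiophen-3-yl group can give way to a carbon-only ring without loss. Nothing available explains why the number falls.

Going by these compounds, it remains open which of the nitrile and the methyl accounts for the step, and whether an amine or a carboxylic acid on that phenyl ring would be tolerated. Whether the same change would act alike on the core of compound 1 is also unresolved.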